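A few compounds are considered here, and "the series" means these few. Any claim that something is new, unique, unknown or untested is made for them only; others in the source may bear on it.

Compound 1 `COc1ccc(Cn2c(CCc3ccccc3)nnc2[C@H](NC(=O)c2ccccn2)c2c[nH]c3ccccc23)cc1` gives 0.7 nM in an in vitro assay on LLC-PK1 cells for displacement of a labelled ligand from growth hormone secretagogue receptor type 1 (Homo sapiens); on this read-out higher numbers stand for weaker inhibition and lower numbers for stronger inhibition. Compound 2 `O=C(N[C@H](c1c[nH]c2ccccc12)c1nnc(CCc2ccccc2)n1-c1ccccc1)c1ccccn1` gives 105 nM in this assay; it differs from compound 1 by phenyl in place of 4-methoxybenzyl on an aromatic nitrogen, and the step is a 150-fold higher number from compound 1 to compound 2 (2.18 log units; beyond the scatter). Compound 3 `COc1ccc(Cn2c(CCc3ccccc3)nnc2[C@H](NC(=O)Cc2ccccn2)c2c[nH]c3ccccc23)cc1` gives 3 nM in this assay; it differs from compound 1 by (pyridin-2-yl)methyl in place of pyridin-2-yl on a carbonyl carbon, a step of a 4.3-fold higher number from compound 1 to compound 3 (0.63 log units; beyond the scatter), so compound 3 stands between the other two measured compounds.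

Compound 4 `O=C(Cc1ccccn1)N[C@H](c1c[nH]c2ccccc12)c1nnc(CCc2ccccc2)n1-c1ccccc1` has not been measured in this assay. It differs from compound 3 by phenyl in place of 4-methoxybenzyl on an aromatic nitrogen, which is the same change as from compound 1 to compound 2, made at the same place on the ring; the two cores differ only by the change described from compound 1 to compound 3. The change has been seen once among these compounds, so the expectation for compound 4 rests on that single step and carries matching uncertainty. The step from compound 3 to compound 4 in this assay is expected to be a 130-fold higher number from compound 3 to compound 4 (2.12 log units; beyond the scatter), taken from the size of a 150-fold higher number from compound 1 to compound 2 (2.18 log units; beyond the scatter). Compound 4 is accordingly estimated at 400 nM in this assay, with a range from 100 nM to 1500 nM.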

Compound 4, half-maximal inhibitory concentration: 700 nM
Estimate against measurement, compound 4: 1.8-fold (0.24 log units) below; the range from low to high includes it.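

In this assay, phenyl in place of 4-methoxybenzyl on the aromatic nitrogen gives a 230-fold higher number from compound 3 to compound 4 (2.37 log units; beyond the scatter), and the size of this step carries over between the two cores: the same change on two cores in this assay, a 150-fold higher number (2.18 log units; beyond the scatter) from compound 1 to compound 2 and a 230-fold higher number (2.37 log units; beyond the scatter) from compound 3 to compound 4, 1.6-fold (0.19 log units) apart, within the scatter of two such steps. The other change, (pyridin-2-yl)methyl in place of pyridin-2-yl on the carbonyl carbon, gives a 6.7-fold higher number from compound 2 to compound 4 (0.82 log units; beyond the scatter) and also holds its size across the two cores: the same change on two cores in this assay, a 4.3-fold higher number (0.63 log units; beyond the scatter) from compound 1 to compound 3 and a 6.7-fold higher number (0.82 log units; beyond the scatter) from compound 2 to compound 4, 1.6-fold (0.19 log units) apart, within the scatter of two such steps. Within these four compounds the two changes therefore act as separate steps, but two cores that differ only at these places do not show that either step would hold on a core changed elsewhere, nor which part of 4-methoxybenzyl accounts for the large step.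

Still open, on these data alone, is how an unsubstituted benzyl or a 4-methoxyphenyl group on that nitrogen would compare, as either would separate the methoxy group from the carbon link to the ring. Phenethyl is also the only group shown at its place, so a shorter chain or an amine there remains untested in these compounds.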